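From a Saturated to an Unsaturated Chain

The source may report more compounds than this note shows. Statements on the series, on what has been measured and on what is new or still open speak of the compounds shown alone.

Compound 1 `CCCCCCCCCCCC(=O)Nc1nnc(S[C@@H]2O[C@H](COC(C)=O)[C@H](OC(C)=O)[C@H](OC(C)=O)[C@H]2OC(C)=O)s1` gives 16900 nM
Compound 2 `CCCCCCCCCCCCCC(=O)Nc1nnc(S[C@@H]2O[C@H](COC(C)=O)[C@H](OC(C)=O)[C@H](OC(C)=O)[C@H]2OC(C)=O)s1` gives 34700 nM
Compound 3 `CCCCCCCCCCCCCCCCCC(=O)Nc1nnc(S[C@@H]2O[C@H](CO)[C@H](O)[C@H](O)[C@H]2O)s1` gives "not active" (no number reported)

Among the measured compounds shown here, in a functional assay on DU-145 cells (Homo sapiens) for cytotoxicity, read by MTT assay, with a stated time of 24 h (on this read-out lower numbers stand for stronger inhibition and higher numbers for weaker inhibition), compound 3 stands without a number, reported as "not active" (no number reported) and so no step can be counted from it. Compound 4 `CCCCCCCC/C=C\CCCCCCCC(=O)Nc1nnc(S[C@@H]2O[C@H](CO)[C@H](O)[C@H](O)[C@H]2O)s1` differs from compound 3 by dec-1-en-1-yl in place of decyl on a saturated chain carbon, seven bonds along the chain from a carbonyl carbon with dec-1-en-1-yl in place of decyl on a saturated chain carbon, seven bonds along the chain from a carbonyl carbon. For the measured compounds named here, the only measured step of a 2.1-fold higher number from compound 1 to compound 2 (0.31 log units; beyond the scatter) is modest and belongs to another pair, so it guides the expected size only loosely. A small step in this assay is therefore expected, leaving compound 4 weak at best or still without a number. The estimate for compound 4 is 50000 nM with an expected range from 15000 nM to 150000 nM if a number is reported.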

Compound 4, half-maximal inhibitory concentration: "not active" (no number reported)
No number was reported for compound 4; the estimate stays without a comparison.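

Compound 3 and compound 4 are both reported as not active, without a number, so no step can be read between them, and no measurement here offers an explanation. On these data alone, whether dec-1-en-1-yl in place of decyl changes the result in this assay at all remains open.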